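The compounds below may be only part of what the source reports. "The series", "measured", "known", "first", "only" and "open" are said of these compounds alone.

Working notes on the series. Compound 1 `CC(=O)Nc1ccc(S(=O)(=O)Nc2ccc(Oc3ccc(F)c(C(F)(F)F)c3)c(C#N)c2)cc1` gives 55% in an assay for inhibition of platelet-activating factor acetylhydrolase (Rattus norvegicus), in plasma, with stated times of 30 min and 10 min, tested at 250 nM; a lower number here means less inhibition, a higher number more inhibition at the concentration tested (going by the name of the read-out). Compound 2 `CC(=O)Nc1ccc(S(=O)(=O)Nc2ccc(Oc3ccc(Cl)c(C(F)(F)F)c3)c(C#N)c2)cc1` gives 64% in this assay, and compound 3 `N#Cc1cc(NS(=O)(=O)c2ccc(N3CCNCC3)cc2)ccc1Oc1ccc(Cl)c(C(F)(F)F)c1` gives 68%. The three numbers lie close together: the number for compound 2 sits inside the span of the other two, and both gaps are within the scatter. The chloro in place of fluoro on an aromatic carbon gave a number 9 percentage points higher from compound 1 to compound 2 (within the scatter); the piperazin-1-yl in place of acetamido on an aromatic carbon gave a number 4 percentage points higher from compound 2 to compound 3 (within the scatter).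

Compound 4 `N#Cc1cc(NS(=O)(=O)c2ccc(NC(=O)N3CCOCC3)cc2)ccc1Oc1ccc(Cl)c(C(F)(F)F)c1` differs from compound 2 in this way: morpholin-4-yl in place of methyl on a carbonyl carbon. For the measured compounds named here, only the second measured step bears on this change, as it also replaces the acetamido end of the shared core; that step was within the scatter, and no step here lies beyond it. The step of a number 2 percentage points lower from compound 2 to compound 4 (within the scatter) is therefore expected to stay within the scatter. For compound 4 the estimate in this assay is 62%, with an expected range from 45% to 78%.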

Compound 4, a percentage reported as inhibition, at one concentration (the size of the read-out at that concentration, not a potency): 64%
For compound 4 the middle estimate is 2 percentage points below the measured one; low and high end bracket the measured number.
By their numbers in this assay, from the lowest: compounds 1, 2, 4 and 3 (each within the scatter of the next, the first and the last beyond it).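

In this assay, the methyl on the carbonyl carbon gives way to morpholin-4-yl, a group of 6 heavy atoms with a six-membered non-aromatic ring, and the step stays small: no change at the digits printed from compound 2 to compound 4 (within the scatter). The urea-type ((morpholin-4-yl)carbonyl)amino group and the piperazin-1-yl group, which differ in how they attach to the aromatic carbon, also remain within the scatter of each other: a number 4 percentage points lower from compound 3 to compound 4 (within the scatter). No measurement shown here explains why these numbers stay so close.

The compounds shown leave open whether a carboxylic acid, a primary amine or a longer alkyl chain on the carbonyl carbon would give a step beyond the scatter. With every number taken at one concentration, any potency differences among these compounds also remain open.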